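Octyl for chlorophenyl on the ring amide carbonyl

The source may hold more compounds than are shown below. What is called first, only, known or untested is meant among the compounds shown, and "the series" means these compounds.

Measured compounds:
compound 1, `O=C(Nc1cc(C(F)(F)F)cc(C(F)(F)F)c1)C1CCc2ccccc2N1C(=O)c1ccccc1Cl` — 8040 nM
compound 2, `O=C(Nc1ccccc1C(F)(F)F)C1CCc2ccccc2N1C(=O)c1ccccc1Cl` — 5140 nM

Both measured compounds share the core of compound 1 and carry a 2-chlorophenylcarbonyl on the ring nitrogen; they differ only in the anilide. In a functional assay on PC-3 cells (Homo sapiens) for cytotoxicity, read by sulforhodamine B assay, with a stated time of 72 h (a higher number here means a weaker inhibitor of growth, a lower number a stronger inhibitor of growth), compound 1 gives 8040 nM, and compound 2 gives 5140 nM. The gap between the two lies within the scatter of this kind of measurement, so the two numbers do not separate compound 1 from compound 2; nothing in these data marks either as the better or worse inhibitor of growth.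

Compound 3, `CCCCCCCCC(=O)N1c2ccccc2CCC1C(=O)Nc1cc(C(F)(F)F)cc(C(F)(F)F)c1`, keeps the bis(trifluoromethyl)anilide of compound 1 and changes the acyl group on the ring nitrogen: octyl in place of 2-chlorophenyl on a carbonyl carbon. Within the data shown here, no pair of measured compounds shows the effect of such a change, and the two numbers so far do not tell whether this part of the molecule matters in this assay.

Among the measured compounds shown here, with no comparable step available, the expectation for compound 3 is a step from compound 1 of roughly the size of the scatter, in no settled direction, so that a 1.3-fold lower number from compound 1 to compound 3 (0.13 log units; within the scatter) is the estimated move. On that basis compound 3 is expected to give about 6000 nM in this assay, with a broad range from 1500 nM to 25000 nM.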

Compound 3, concentration for 50% growth inhibition: 7430 nM
The estimate for compound 3 lay 1.2-fold (0.09 log units) below the measured number, within the range that was stated.
By their numbers in this assay, from the lowest: compounds 2, 3 and 1 (each within the scatter of the next).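

In this assay, among these compounds, octyl in place of 2-chlorophenyl on a carbonyl carbon gives a 1.1-fold lower number from compound 1 to compound 3 (0.03 log units; within the scatter), the first step that changes the acyl group on the ring nitrogen while the anilide stays fixed. With this anilide, the numbers do not tell an octyl chain from a 2-chlorophenyl ring at this place, so the aromatic ring and its chlorine are not needed to reach the level of growth inhibition that compound 1 shows. Nothing measured here speaks to why the two groups read alike.

Going by these compounds, it remains open whether octylcarbonyl reads the same on the anilide of compound 2, since this single step covers only the bis(trifluoromethyl)anilide. On these data alone, it is equally open whether a much shorter chain such as methyl, a longer chain, or a chain ending in a carboxylic acid or an amine would move the number beyond the scatter at this place, or whether the number stays insensitive to what sits on this carbonyl carbon.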